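Swapping the ring on the sulfur of compound 1

The source may report more compounds than this note shows. Statements on the series, on what has been measured and on what is new or still open speak of the compounds shown alone.

Measured compounds:
- compound 1 `Cn1c(-c2ccc(NC(=O)CSc3nc4ccccc4o3)cc2)nc(-c2ccccc2)c1-c1ccccc1`: 79.3%
- compound 2 `Cc1ccc2oc(SCC(=O)Nc3ccc(-c4nc(-c5ccccc5)c(-c5ccccc5)n4C)cc3)nc2c1`: 59.5%
- compound 3 `Cn1c(-c2ccc(NC(=O)CSc3nc4ccccc4s3)cc2)nc(-c2ccccc2)c1-c1ccccc1`: 66%

In a functional assay on HT-29 cells (Homo sapiens) for cytotoxicity, read by MTT assay, with a stated time of 24 h, tested at 32 ug/mL (on this read-out higher numbers stand for a stronger effect at the one concentration tested and lower numbers for a weaker effect), compound 1 gives 79.3%, the highest of the three numbers. Compound 3 stands nearest, and compound 2 furthest, and both steps away from compound 1 are beyond the scatter. The two measured steps each alter the ring that hangs on the sulfur: a number 19.8 percentage points lower from compound 1 to compound 2 (beyond the scatter), and a number 13.3 percentage points lower from compound 1 to compound 3 (beyond the scatter). Between compounds 2 and 3 the step is a number 6.5 percentage points higher from compound 2 to compound 3 (within the scatter).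

Compound 4 `Cc1nnc(SCC(=O)Nc2ccc(-c3nc(-c4ccccc4)c(-c4ccccc4)n3C)cc2)s1` has not yet been tested in this assay. Compared with compound 1, the difference is 5-methyl-1,3,4-thiadiazol-2-yl in place of 1,3-benzoxazol-2-yl on a sulfur. Among the compounds with values here, no measured step matches this change, since both earlier steps kept a two-ring group on the sulfur, whereas here a single five-membered ring with three hetero atoms enters. Within the data shown here, what the measured steps do show is that each change to this ring so far moved the number down by a modest amount, so a modest decrease is the expectation, with wide uncertainty because a smaller, different ring has no precedent here. Compound 4 is therefore estimated at 58%, within 35% to 78%, a step of a number 21.3 percentage points lower from compound 1 to compound 4 (beyond the scatter).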

Compound 4, a percentage reported as activity, at one concentration (the size of the read-out at that concentration, not a potency): 87.1%
Compound 4: the middle estimate sits 29.1 percentage points below what was measured; measured number outside the range, above it.
By their numbers in this assay, from the lowest: compounds 2 and 3 (each within the scatter of the next); then compounds 1 and 4 (each within the scatter of the next).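

In this assay, a two-ring group on the sulfur proves not to be required: the single five-membered aromatic ring of compound 4, 5-methyl-1,3,4-thiadiazol-2-yl, carries fewer heavy atoms than the 1,3-benzoxazol-2-yl it replaces, yet the outcome is a number 7.8 percentage points higher from compound 1 to compound 4 (within the scatter). Within the data shown here, this is the first change away from compound 1 that does not lower the number beyond the scatter, and the same ring also compares well with the other two-ring groups, with a number 21.1 percentage points higher from compound 3 to compound 4 (beyond the scatter) and a number 27.6 percentage points higher from compound 2 to compound 4 (beyond the scatter). The information shown offers no measurement that would explain why this ring behaves so differently from those two groups.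

The compounds shown leave open whether the methyl on the 5-methyl-1,3,4-thiadiazol-2-yl ring contributes at all, a question that a plain hydrogen, a longer ethyl chain or an amine at that place could address. They also leave open how these compounds compare in potency, since each number here comes from a single concentration and a full concentration series would be needed to settle that.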